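A few compounds are considered here, and "the series" means these few. Any claim that something is new, unique, unknown or untested is made for them only; others in the source may bear on it.

Measured in a functional assay on U-87MG ATCC cells (Homo sapiens) for antiproliferative activity; on this read-out higher numbers stand for weaker inhibition and lower numbers for stronger inhibition:

- Compound 1 `Cc1c2c(n3c1CCCNC[C@H](C)Nc1cc-3ccc1C(N)=O)CC(C)(C)CC2=O`: 366 nM
- Compound 2 `Cc1c2c(n3c1CCNC[C@@H](C)[C@H](C)Nc1cc-3ccc1C(N)=O)CC(C)(C)CC2=O`: 40 nM
- Compound 3 `CC[C@H](N)C(=O)N1CCc2c(C)c3c(n2-c2ccc(C(N)=O)c(c2)N[C@@H](C)[C@H](C)C1)CC(C)(C)CC3=O`: 45 nM

Compound 2 and compound 3 stand together at the low end of these numbers, within the usual scatter of each other. Compound 1 lies beyond that scatter from compound 2, on the higher, weaker side.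

Compound 4 `Cc1c2c(n3c1CCN(C(=O)C1(N)CC1)C[C@@H](C)[C@H](C)Nc1cc-3ccc1C(N)=O)CC(C)(C)CC2=O` has not yet been measured. It keeps the core of compound 2 and carries (1-aminocyclopropyl)carbonyl in place of hydrogen on an amine nitrogen in a ring.

Among the measured compounds shown here, one measured step bears directly on this change. With (1-aminopropyl)carbonyl in place of hydrogen on an amine nitrogen in a ring, the result was a 1.1-fold higher number from compound 2 to compound 3 (0.05 log units; within the scatter). For the measured compounds named here, the group in compound 4 differs from that one by its three-membered ring of carbon, and no measured compound shows what such a ring does here. Going by compound 3 at 45 nM, no step beyond the scatter is expected in this assay, although a single example is thin support. The step expected is a 1.1-fold higher number from compound 2 to compound 4 (0.05 log units; within the scatter). For compound 4 the estimated value is 45 nM, with an expected range from 18 nM to 110 nM.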

Compound 4, half-maximal inhibitory concentration: 85 nM
Compound 4: the middle estimate sits 1.9-fold (0.28 log units) below what was measured; low and high end bracket the measured number.
By their numbers in this assay, from the lowest: compounds 2, 3 and 4 (each within the scatter of the next, the first and the last beyond it); then compound 1.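

In this assay, putting (1-aminocyclopropyl)carbonyl on the amine nitrogen in the ring gives a 2.1-fold higher number from compound 2 to compound 4 (0.33 log units; beyond the scatter), so this nitrogen does not accept every acyl group without a measurable shift, even though the earlier example stayed at a 1.1-fold higher number from compound 2 to compound 3 (0.05 log units; within the scatter). The shift is modest, however, and the direct comparison of the two groups on the carbonyl carbon, 1-aminocyclopropyl in place of 1-aminopropyl, gives a 1.9-fold higher number from compound 3 to compound 4 (0.28 log units; within the scatter), so the three-membered ring cannot be told apart from the open chain in this assay, and compounds 3 and 4 read as one level. Among the compounds shown here, nothing available explains why only the step to compound 4 passes beyond the scatter.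

From the compounds shown here alone, it remains open how much the amine on these groups contributes, which a plain acetyl group on the same nitrogen would help to show. Going by these compounds, it is also open whether a larger ring, as in (1-aminocyclobutyl)carbonyl, or a longer chain on the carbonyl carbon would stay at this level or move further from compound 2.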